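The source may hold more compounds than are shown below. What is called first, only, known or untested is meant among the compounds shown, and "the series" means these compounds.

Measured compounds:
Compound 1, `O=C(Nc1cccc(Br)c1)C(Cl)Cl` — 7720 nM
Compound 2, `O=C(Nc1cccc(I)c1)C(Cl)Cl` — 5390 nM
Compound 3, `O=C(Nc1ccc(Br)cc1)C(Cl)Cl` — 9770 nM

Three compounds have been examined in a functional assay on Bel-7402 cells (Homo sapiens) for antiproliferative activity, read by MTT assay, with a stated time of 72 h (a lower number here means a stronger inhibitor, a higher number a weaker inhibitor), and a fourth, compound 4 with the structure `O=C(Nc1ccc(I)cc1)C(Cl)Cl`, is still to be measured there.

Compound 1 and compound 2 share a core and differ in one place: iodo in place of bromo on an aromatic carbon. That change produced a step of a 1.4-fold lower number from compound 1 to compound 2 (0.16 log units; within the scatter). Compound 3 has the same atoms as compound 1, joined differently; the difference between the two cores is not broken down here. In this assay compound 3 gives 9770 nM, which sits within the scatter of the values of compound 1 and compound 2, so no order among the three can be stated.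

Compound 4 stands to compound 3 as compound 2 stands to compound 1: iodo in place of bromo on an aromatic carbon. Within the data shown here, this is the same kind of change as the one from compound 1 to compound 2, not the same change. In the earlier pair the group sits meta to a group of 6 heavy atoms; here it sits para to a group of 6 heavy atoms. With a single precedent, the expectation for compound 4 rests on the step of a 1.4-fold lower number from compound 1 to compound 2 (0.16 log units; within the scatter), and the expected step is a 1.4-fold lower number from compound 3 to compound 4 (0.14 log units; within the scatter). Compound 4 is therefore estimated at 7000 nM, with a range from 3000 nM to 16000 nM.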

Compound 4, half-maximal inhibitory concentration: 11900 nM
Beside the measured number, compound 4's estimate is 1.7-fold (0.23 log units) below it; the measured number falls inside the stated range.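

In this assay, iodo in place of bromo, now read on a second core, gives a 1.2-fold higher number from compound 3 to compound 4 (0.09 log units; within the scatter), and the two readings of this change can be set side by side: the same change on two cores in this assay, a 1.4-fold lower number (0.16 log units; within the scatter) from compound 1 to compound 2 and a 1.2-fold higher number (0.09 log units; within the scatter) from compound 3 to compound 4, 1.7-fold (0.24 log units) apart, within the scatter of two such steps

Within these four compounds, the swap left the number inside the usual scatter on the core of compound 1 and on the core of compound 3, and the two steps cannot be told apart, so the change behaves alike on both cores as far as this assay can resolve. This does not show that the change carries a fixed size or direction from one core to another: the printed steps run opposite ways, but neither is large enough for a direction to be assigned, and two steps this small cannot test whether a change with a real effect would transfer between the cores.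

The compounds shown carry only bromo or iodo on the aromatic ring, so it stays open whether an amine, a carboxylic acid or a longer chain on that ring would give a value outside the scatter of these four. Also open, from the compounds shown here alone, is whether either position on the ring would matter once such a group stands there.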